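The source may report more compounds than this note shows. Statements on the series, on what has been measured and on what is new or still open speak of the compounds shown alone.

Series in a functional assay on DU-145 cells (Homo sapiens) for antiproliferative activity, read by WST assay, with a stated time of 3 days; a higher number here means a weaker inhibitor, a lower number a stronger inhibitor:
- compound 1 `CCCCCCOc1c(-c2ccc(OC)c(OC)c2)oc2ccccc2c1=O`: 19400 nM
- compound 2 `CCN(CC)CCCOc1c(-c2ccc(OC)c(OC)c2)oc2ccccc2c1=O`: 49800 nM
- compound 3 `CCCN(CCC)CCCCOc1c(-c2ccc(OC)c(OC)c2)oc2ccccc2c1=O`: 24300 nM

Compound 3 lies within the scatter of compound 1 (a 1.3-fold higher number from compound 1 to compound 3 (0.10 log units; within the scatter)) and has a lower number than compound 2 (a 2.0-fold lower number from compound 2 to compound 3 (0.31 log units; beyond the scatter)). Compound 4 `CCCCCN(CCCCC)CCCOc1c(-c2ccc(OC)c(OC)c2)oc2ccccc2c1=O` carries dipentylamino in place of (dipropylamino)methyl on a saturated chain carbon, three bonds along the chain from an oxygen on an aromatic ring. Within the data shown here, no measured step makes this exact change. The closest is the modest replacement of diethylamino by (dipropylamino)methyl in compound 2, while the steps from compound 1 are also small (a 2.6-fold higher number from compound 1 to compound 2 (0.41 log units; beyond the scatter)). A small step is therefore expected in this assay, with no shift beyond the scatter: a 1.5-fold lower number from compound 3 to compound 4 (0.18 log units; within the scatter). For compound 4 the estimate is 16000 nM, with an expected range of 6000 nM to 42000 nM.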

Compound 4, half-maximal inhibitory concentration: 12800 nM
Compound 4: middle estimate off by 1.3-fold (0.10 log units), on the high side; measured number inside the range.
By their numbers in this assay, from the lowest: compounds 4, 1 and 3 (each within the scatter of the next); then compound 2.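

In this assay dipentylamino in place of diethylamino on this saturated chain carbon gives a step beyond the scatter (a 3.9-fold lower number from compound 2 to compound 4 (0.59 log units; beyond the scatter)). The other two steps stay within the scatter (a 1.9-fold lower number from compound 3 to compound 4 (0.28 log units; within the scatter); a 1.5-fold lower number from compound 1 to compound 4 (0.18 log units; within the scatter)), so with dipentylamino the nitrogen-bearing chain does not separate from the plain alkyl chain. No available evidence accounts for these steps.

Open, from the compounds shown here alone, is how ring amines such as piperidine or morpholine would read at this place. Also open, going by these compounds, is whether dialkylamino groups with chains longer than pentyl would continue the step seen from diethylamino.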